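The source may report more compounds than this note shows. Statements on the series, on what has been measured and on what is new or still open speak of the compounds shown alone.

Of the compounds shown here, three sharing one core have been measured so far in an ADME assay on the whole organism (plasma, Rattus norvegicus) for protein binding, using cassette dosing, at a dose of 1 mg/kg (a lower number here means a smaller unbound share, a higher number a larger unbound share of the compound), and they span a wide range. Compound 1 `CC(C)Oc1ccc(/N=c2\[nH]c(=O)n(C[C@@H](O)CO)c(=O)n2Cc2ccc(Cl)cc2)cc1Cl` gives 0.001 and compound 3 `CC(C)Oc1ccc(/N=c2\[nH]c(=O)n(C[C@H](C)C(=O)O)c(=O)n2Cc2ccc(Cl)cc2)cc1Cl` gives 0.003 while compound 2 `C[C@@H](Cn1c(=O)[nH]/c(=N\c2ccc(Oc3cnccn3)cc2)n(Cc2ccc(Cl)cc2)c1=O)C(=O)O` gives 0.018 as the highest of the three. Compound 4 `C[C@@H](Cn1c(=O)[nH]/c(=N\c2ccc(Oc3ccsn3)cc2)n(Cc2ccc(Cl)cc2)c1=O)C(=O)O` departs from compound 2 in a single place, on an oxygen on an aromatic ring: 1,2-thiazol-3-yl in place of pyrazin-2-yl on an oxygen on an aromatic ring and the rest of the structure stays the same. Among the compounds with values here, no measured step touches this group. Within the data shown here, the only step available is a 3.0-fold higher number from compound 1 to compound 3 (0.48 log units; beyond the scatter) and it lies elsewhere, on a saturated chain carbon bound to an aromatic nitrogen, so it shows what one local change can do in this assay but sets no direction here. No shift beyond the scatter is therefore expected, and the estimated change is a 1.4-fold lower number from compound 2 to compound 4 (0.14 log units; within the scatter) with real uncertainty either way. Compound 4 is expected to read 0.013 with an estimated range from 0.005 to 0.03 in this measurement.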

Compound 4, unbound fraction: 0.012
Compound 4: middle estimate off by 1.1-fold (0.03 log units), on the high side; measured number inside the range.
By their numbers in this assay, from the lowest: compound 1; then compound 3; then compounds 4 and 2 (each within the scatter of the next).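

In this assay, the change of pyrazin-2-yl to 1,2-thiazol-3-yl on an oxygen on an aromatic ring gives a 1.5-fold lower number from compound 2 to compound 4 (0.18 log units; within the scatter) and so cannot be told apart from repeat-measurement noise. Within the data shown here, this is the first reading at this position, and it shows that a six-membered aromatic ring can give way to a five-membered one here without a clear shift in the unbound fraction. Nothing available explains this result.

One swap between two aromatic rings says little about the position as a whole, so a plain phenyl ring or a chain ending in an amine on this oxygen might still move the number beyond the scatter. As far as these compounds go, it also remains open whether the same swap would behave alike with 1,2-dihydroxyethyl on the saturated chain carbon instead of 1-carboxyethyl.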